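The source may report more compounds than this note shows. Statements on the series, on what has been measured and on what is new or still open speak of the compounds shown alone.

Working notes on the series.

Compound 1 `COC(=O)c1c(-c2ccc(OCc3ccccc3)cc2)oc2ccccc2c1=O` is the parent. In a functional assay on A549 cells (Homo sapiens) for cytotoxicity, read by MTT assay, with a stated time of 6 days (on this read-out lower numbers stand for an effect already at smaller amounts and higher numbers for an effect only at larger amounts of compound), compound 1 reaches only the limit > 25 ug/mL, with no number behind it. Compound 2 `COC(=O)c1c(-c2ccc(OCc3ccccc3)cc2)oc2ccc(OC)cc2c1=O` carries the change methoxy in place of hydrogen on an aromatic carbon on the core of compound 1; in this assay compound 2 gives 22.1 ug/mL, and the step is an at least 1.1-fold lower number from compound 1 to compound 2 (0.05 log units; that floor lies within the scatter). Compound 3 `COC(=O)c1c(-c2ccc(O)cc2)oc2ccccc2c1=O` differs from compound 1 by hydrogen in place of benzyl on an oxygen on an aromatic ring; in this assay compound 3 also sits at the limit > 25 ug/mL, so the step that the two limits leave unreadable from compound 1 to compound 3 cannot be read. Two of the three values stop at the same limit (the limit of > 25 ug/mL in this assay, at which 2 of the 3 values shown sit).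

Compound 4 `COC(=O)c1c(-c2ccc(O)cc2)oc2cc(OC)ccc2c1=O` is not yet measured. It differs from compound 3 by methoxy in place of hydrogen on an aromatic carbon, the same change as from compound 1 to compound 2, at the same place. On that one example, which stayed within the scatter, the step that the limit leaves unreadable from compound 3 to compound 4 in this assay is expected to be small, resting on an at least 1.1-fold lower number from compound 1 to compound 2 (0.05 log units; that floor lies within the scatter) and on the limit of compound 3. Compound 4 is therefore estimated near 28 ug/mL in this assay, between 14 ug/mL and 60 ug/mL, with a fair chance that only a limit is reported.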

Compound 4, concentration for half-maximal effect: > 25 ug/mL
Compound 4: no number, only a limit; the forecaster's own chance of this, stated with the estimate: 50%; the middle value is on the limit's open side.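

Compound 4 gives only a limit (> 25 ug/mL) in this assay, and compound 3 also stops at a limit, so no step between compound 3 and compound 4 can be read: the limit of > 25 ug/mL in this assay, at which 3 of the 4 values shown sit.

The compounds shown leave open how far compound 1, compound 3 and compound 4 lie past that limit, and whether methoxy in place of hydrogen on an aromatic carbon changes the read-out on compound 3.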